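The compounds below may be only part of what the source reports. "The series", "measured", "known", "first", "only" and "open" are said of these compounds alone.

Compounds measured: compound 2 `Nc1ccccc1NC(=O)c1ccc(CNC2=NC[C@@H](c3ccccc3)S2)cc1` with 1400 nM and compound 1 `Nc1ccccc1NC(=O)c1ccc(CNC2=N[C@@H](Cc3ccccc3)CS2)cc1` with 34900 nM.

In an assay for inhibition of histone deacetylase 8 (Homo sapiens), read by fluorescence, with stated times of 15 min and 60 min (on this read-out higher numbers stand for weaker inhibition and lower numbers for stronger inhibition), compound 2 gives 1400 nM, the lowest of the two numbers, while compound 1 gives 34900 nM. Compound 3 `Nc1ccccc1NC(=O)c1ccc(CNC2=NC[C@H](c3ccccc3)S2)cc1` is the unmeasured counterpart: the two compounds have the same atoms and bonds and differ only in configuration as drawn: 1 of 1 stereo elements differ; a stereocentre at a saturated ring carbon is drawn R in compound 2 and S in compound 3. Among the compounds with values here, no measured pair here shows what such an inversion alone does, so the direction is open; a mirror-image change often costs some inhibition, and a step of that kind is expected, with the chance that the number is unchanged within the scatter. Compound 3 is estimated at 4000 nM, between 800 nM and 25000 nM, a step of a 2.9-fold higher number from compound 2 to compound 3 (0.46 log units; beyond the scatter).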

Compound 3, half-maximal inhibitory concentration: 2300 nM
Compound 3: middle estimate off by 1.7-fold (0.24 log units), on the high side; low and high end bracket the measured number.
By their numbers in this assay, from the lowest: compounds 2 and 3 (each within the scatter of the next); then compound 1.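

Within the data shown here, this pair is the first clean test of a single stereocentre, which the earlier compounds could not give: the fact that compounds 2 and 3 differ only in the configuration as drawn. In this assay, inverting the saturated ring carbon gives a 1.6-fold higher number from compound 2 to compound 3 (0.22 log units; within the scatter), so the R and S forms cannot be told apart here. Inhibition at this position therefore shows no measurable dependence on the configuration as drawn.

From the compounds shown here alone, it remains open whether this tolerance would hold if an amine or a carboxylic acid replaced the present substituent at this stereocentre. The compounds shown also leave open whether the two forms would still match with such a group in place.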